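A few compounds are considered here, and "the series" means these few. Any claim that something is new, unique, unknown or untested is made for them only; others in the source may bear on it.

Compound 1 `COC(=O)[C@@]1(C)CCC=C2[C@@H]1CC[C@@H](C)[C@]2(C)Cc1c(C)[nH]c2ccc(Br)cc12` and compound 2 `COC(=O)[C@@]1(C)CCC=C2[C@@H]1CC[C@@H](C)[C@]2(C)Cc1c(C)[nH]c2ccc(OC)cc12` share one core; compound 3 `COC(=O)[C@@]1(C)CC[C@@H]2C3=C1CC[C@@H](C)[C@]3(C)Cc1c2[nH]c2ccc(Br)cc12` and compound 4 `COC(=O)[C@@]1(C)CC[C@@H]2C3=C1CC[C@@H](C)[C@]3(C)Cc1c2[nH]c2ccc(OC)cc12` share another, and the difference between the two cores is not broken down here. In a functional assay on HBL-100 cells (Homo sapiens) for inhibition, read by sulforhodamine B assay, with a stated time of 48 h (a lower number here means a stronger inhibitor of growth, a higher number a weaker inhibitor of growth), compound 1 gives 15000 nM, compound 2 gives 16000 nM and compound 3 gives 16000 nM; these three numbers lie within the scatter of one another, so no order among them is claimed. Within the first core the change methoxy in place of bromo on an aromatic carbon gives a 1.1-fold higher number from compound 1 to compound 2 (0.03 log units; within the scatter). Compound 4 arises from compound 3 by methoxy in place of bromo on an aromatic carbon. This is the same kind of change, not the same: the six-membered aromatic ring of carbon only that carries it is part of a fused or bridged system of two rings in the first pair and of five rings in the second. Compound 4 has not yet been measured in this assay. Within the data shown here, the expected step is a 1.1-fold higher number from compound 3 to compound 4 (0.03 log units; within the scatter), because the earlier change measured a 1.1-fold higher number from compound 1 to compound 2 (0.03 log units; within the scatter) and nothing among the measured compounds points the other way. Compound 4 is therefore estimated at 17000 nM, with a range from 8500 nM to 34000 nM.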

Compound 4, concentration for 50% growth inhibition: 5000 nM
Compound 4: middle estimate off by 3.4-fold (0.53 log units), on the high side; measured number outside the range, below it.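

In this assay, methoxy in place of bromo on an aromatic carbon gives a 3.2-fold lower number from compound 3 to compound 4 (0.51 log units; beyond the scatter), a modest step. The change therefore does not carry over with the same size from one core to the other: the same change on two cores in this assay, a 1.1-fold higher number (0.03 log units; within the scatter) from compound 1 to compound 2 and a 3.2-fold lower number (0.51 log units; beyond the scatter) from compound 3 to compound 4, 3.4-fold (0.53 log units) apart, beyond the scatter of two such steps

Among these compounds, with only one pair on each core, this shows that the core can matter to the outcome of this exchange, but it does not show which part of the core is responsible, or whether the gap would recur with any other pair of groups.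

Open, as far as these compounds go, is whether the gain seen with methoxy on the second core is particular to that group, or whether an amine, a hydroxyl or a longer chain such as butoxy on the same aromatic carbon would also give a lower number there. Also open, from the compounds shown here alone, is whether any such group would leave the number flat on the first core, as methoxy does.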